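Swapping bromo for chloro in a cytotoxicity series

The source may report more compounds than this note shows. Statements on the series, on what has been measured and on what is new or still open speak of the compounds shown alone.

Measured compounds:
compound 1 `COc1nc(-c2cccc(Cl)c2)ccc1[C@@H](c1ccccc1)[C@@](O)(CCN(C)C)c1cccc2ccccc12`: "nd" (no result reported)
compound 2 `COc1nc(-c2ccc(Br)cc2)ccc1[C@@H](c1ccccc1)[C@@](O)(CCN(C)C)c1cccc2ccccc12`: > 64 ug/mL
compound 3 `COc1nc(-c2ccsc2)ccc1[C@@H](c1ccccc1)[C@@](O)(CCN(C)C)c1cccc2ccccc12`: > 64 ug/mL

In a toxicity assay on HeLa cells (Homo sapiens) for cytotoxicity (a higher number here means that more compound is tolerated, a lower number that less compound is tolerated), compound 2 gives only a limit, > 64 ug/mL. Compound 3 likewise reaches only a limit, > 64 ug/mL, so the step that the two limits leave unreadable from compound 2 to compound 3 cannot be read as a number. Compound 1 has no result here. Compound 4 `COc1nc(-c2ccc(Cl)cc2)ccc1[C@@H](c1ccccc1)[C@@](O)(CCN(C)C)c1cccc2ccccc12` differs from compound 2 by chloro in place of bromo on an aromatic carbon. Among the compounds with values here, no measured step covers this exchange, and the only firm point is the limit of > 64 ug/mL in this assay, at which 2 of the 3 values shown sit. Since compound 2 itself sits at that limit, compound 4 is expected to sit there too, with a step that the limit leaves unreadable from compound 2 to compound 4 expected to be no step beyond the scatter. Compound 4 is therefore estimated at 90 ug/mL, within 50 ug/mL to 200 ug/mL.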

Compound 4, half-maximal cytotoxic concentration: > 64 ug/mL
Compound 4: only a limit was reported; the forecaster's own chance of this, stated with the estimate: 85%; the middle value does not contradict the limit.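

In this assay compound 4 gives > 64 ug/mL, which is only a limit. Within the data shown here, compound 2 and compound 3 also give limits, so no step to compound 4 can be read. The compounds shown leave open whether chloro and bromo differ here.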